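Acid-to-amide exchange on the CDK8 series

This account rests on a few compounds, and the source may have more. Where it says the series, first, only, none or still open, it means among the compounds named here.

Of the compounds shown here, two have been measured in an assay on a protein complex for inhibition of CDK8/Cyclin C (Homo sapiens), with a stated time of 1 h, tested at 10 uM; on this read-out lower numbers stand for less inhibition and higher numbers for more inhibition at the one concentration tested (going by the name of the read-out). Compound 1 `Cn1ccc2cc(-c3cnccc3/C=C/C(=O)O)ccc21` gives 102% in this assay. Compound 2 `CNC(=O)CCc1ccncc1-c1ccc2ccccc2c1`, which carries a methylcarbamoyl group on a saturated chain, gives 100% in this assay. The two numbers lie within the scatter of each other, so neither compound can be set above the other; the two numbers are level.

Compound 3 `CNC(=O)/C=C/c1ccncc1-c1ccc2c(ccn2C)c1` has not yet been measured. It differs from compound 1 by one change: methylamino in place of hydroxy on a carbonyl carbon. Going by the values given here, no step between measured compounds is available for this change, so its size cannot be read from the present data. Among the compounds with values here, the only hint is that compound 2, also bearing a methylcarbamoyl group, gives 100% in this assay, a number at the top of the scale.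

The step from compound 1 to compound 3 is therefore expected to be small, a number 7 percentage points lower from compound 1 to compound 3 (within the scatter), probably no larger than the scatter and, if anything, downward. Compound 3 is expected to give about 95% in this assay, with a range from 75% to 105%.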

Compound 3, a percentage reported as inhibition, at one concentration (the size of the read-out at that concentration, not a potency): 99%
Beside the measured number, compound 3's estimate is 4 percentage points below it; low and high end bracket the measured number.
By their numbers in this assay, from the lowest: compounds 3, 2 and 1 (each within the scatter of the next).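

In this assay, methylamino in place of hydroxy on a carbonyl carbon gives a number 3 percentage points lower from compound 1 to compound 3 (within the scatter), the first step read directly at this position on the shared core. Within this pair, carboxy and methylcarbamoyl on the ethenyl chain are therefore level, so the carboxy group is not required for a number at the top of the scale, with compound 1 at 102% and compound 3 at 99% in this read-out taken at one concentration, which gives a size and not a potency. No measurement shown bears on why the exchange leaves the number level.

Still open, as far as these compounds go, is whether other groups on the same carbonyl carbon, such as amino, dimethylamino, methoxy or a longer chain on the amide nitrogen, would stay level with compound 3 or fall beyond the scatter. Also open, from the compounds shown here alone, is whether compound 1 and compound 3 would stay level at lower test concentrations, where numbers would no longer sit at the top of the scale and a full potency comparison of the acid and the amide could be read.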